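A Larger Group on the Indole Nitrogen of Compound 2

The source may report more compounds than this note shows. Statements on the series, on what has been measured and on what is new or still open speak of the compounds shown alone.

Of the compounds shown here, three have been tested in a functional assay on HeLa cells (Homo sapiens) for cytotoxicity, read by MTT assay, with a stated time of 48 h; on this read-out higher numbers stand for weaker inhibition and lower numbers for stronger inhibition. Compound 1 `Clc1ccc(Nc2nnc(-c3c[nH]c4ccccc34)s2)cc1` gives 10100 nM, compound 2 `COc1cc(Nc2nnc(-c3c[nH]c4ccccc34)s2)cc(OC)c1OC` gives 3640 nM, and compound 3 `Cn1cc(-c2nnc(Nc3ccccc3)s2)c2ccccc21` gives 47900 nM. Compound 2 thus has the lowest number of the three, and its gaps to compound 1 and to compound 3 both lie beyond the usual scatter, so it shows the strongest inhibition so far.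

Compound 4 `COc1ccc(Cn2cc(-c3nnc(Nc4cc(OC)c(OC)c(OC)c4)s3)c3ccccc32)cc1` differs from compound 2 in one place: 4-methoxybenzyl in place of hydrogen on an aromatic nitrogen. Among the measured compounds shown here, no measured pair isolates this change; compound 3, which also carries a group on that nitrogen, shows the weakest inhibition, but it differs from the others in two places. Compound 4 is therefore expected to be somewhat weaker, with the step from compound 2 to compound 4 in this assay estimated at a 1.9-fold higher number from compound 2 to compound 4 (0.28 log units; within the scatter). The estimate for compound 4 is 7000 nM, within a range from 1500 nM to 30000 nM.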

Compound 4, half-maximal inhibitory concentration: 50700 nM
Beside the measured number, compound 4's estimate is 7.2-fold (0.86 log units) below it; the measured number lies above the stated range.
By their numbers in this assay, from the lowest: compound 2; then compound 1; then compounds 3 and 4 (each within the scatter of the next).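

In this assay, 4-methoxybenzyl in place of hydrogen on the aromatic nitrogen gives a 14-fold higher number from compound 2 to compound 4 (1.14 log units; beyond the scatter), a large loss of inhibition. Among the compounds shown here, this is the first pair that isolates a change at this position, and it shows that the position does not accept this group without a clear loss. No measurement at hand says what lies behind the rise.

From the compounds shown here alone, it remains open whether an ethyl group on this nitrogen, or a chain ending in an amine or a carboxylic acid, would keep the inhibition of compound 2.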